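The compounds below may be only part of what the source reports. "The series", "measured", "known", "first", "only" and "open" are said of these compounds alone.

Compound 1 `CON=C1CCC(N(C)N2CCN(c3nc(=O)c4cc(C(F)(F)F)cc([N+](=O)[O-])c4s3)CC2)CC1` is the reference point of this set. In an ADME assay on Vero cells (Chlorocebus sabaeus) for cytotoxicity, read by MTT assay, with a stated time of 72 h (on this read-out lower numbers stand for higher toxicity in this test and higher numbers for lower toxicity in this test), compound 1 returns a limit of > 64 ug/mL rather than a number. Compound 2 `O=c1nc(N2CCN(NCc3cccc(C(F)(F)F)c3)CC2)sc2c([N+](=O)[O-])cc(C(F)(F)F)cc12` likewise reaches only a limit in this assay, reading > 64 ug/mL. Compound 3 `C/C(=N\N1CCN(c2nc(=O)c3cc(C(F)(F)F)cc([N+](=O)[O-])c3s2)CC1)c1ccc(OC(F)(F)F)cc1` gives a limit as well in this assay, at > 64 ug/mL. Among the measured compounds shown here, the one single-point step within the set is a step that the two limits leave unreadable from compound 1 to compound 2; both of its ends are limits, so its size cannot be read. Compound 2 therefore stands at the limit of this assay, indistinguishable from compound 1 and compound 3, as the limit of > 64 ug/mL in this assay, at which 3 of the 3 values shown sit, records.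

Compound 4 `O=c1nc(N2CCN(Nc3ccc(OC(F)(F)F)cc3)CC2)sc2c([N+](=O)[O-])cc(C(F)(F)F)cc12` is not yet measured. It differs from compound 2 in one place: 4-(trifluoromethoxy)phenyl in place of 3-(trifluoromethyl)benzyl on an amine nitrogen. No measured step bears directly on this change, and the only step shown left both of its ends at the limit, so no size can be carried over from it. With every value shown sitting at the limit, the expectation for compound 4 in this assay is a step that the limit leaves unreadable from compound 2 to compound 4, none beyond the scatter, and most probably another limit. Compound 4 is estimated at 100 ug/mL, with a range from 50 ug/mL to 250 ug/mL.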

Compound 4, half-maximal cytotoxic concentration: > 64 ug/mL
Compound 4: only a limit was reported; the forecaster's own chance of this, stated with the estimate: 85%; the middle value is on the limit's open side.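

In this assay compound 4 gives > 64 ug/mL, a limit and not a number. The steps from compound 1 and compound 2 to compound 4 cannot be read, as both ends of each are limits. Whether any group on this amine nitrogen shifts the half-maximal cytotoxic concentration stays open, with every compound shown resting at one value: the limit of > 64 ug/mL in this assay, at which 4 of the 4 values shown sit.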